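Losing a Chloro Group: Expected Effect on Cell Inhibition

A few compounds are considered here, and "the series" means these few. Any claim that something is new, unique, unknown or untested is made for them only; others in the source may bear on it.

compound 1, `COc1cc(Cl)cc(-c2nn(-c3cccc(NC(=O)Nc4ccc(Cl)c(C(F)(F)F)c4)c3)cc2-c2ccncc2)c1`: -77%
compound 2, `COc1cc(Cl)cc(-c2nn(-c3cccc(NC(=O)Nc4cc(C(F)(F)F)cc(C(F)(F)F)c4)c3)cc2-c2ccncc2)c1`: -70%

Going by the values given here, in a functional assay on SK-MEL-5 cells (Homo sapiens) for inhibition, read by sulforhodamine B assay, with a stated time of 48 h, tested at 100 uM (a lower number here means a stronger effect, a higher number a weaker effect of the compound at the concentration tested), compound 1 gives -77%, the lowest of the two numbers measured so far. Compound 2 gives -70% in this assay, and the two values sit close together, so neither can be called the stronger of the pair. Compound 3, `COc1cc(Cl)cc(-c2nn(-c3cccc(NC(=O)Nc4cccc(C(F)(F)F)c4)c3)cc2-c2ccncc2)c1`, has not yet been measured. Relative to compound 1 it carries hydrogen in place of chloro on an aromatic carbon. Among the compounds with values here, no step between measured compounds exists to gauge a change of this kind, so the expectation for compound 3 rests on compound 1 at -77% alone. A modest move toward a higher number in this assay is expected, of a size near the edge of the usual scatter rather than a large loss of effect. The step expected is a number 12 percentage points higher from compound 1 to compound 3 (beyond the scatter). For compound 3 the estimate is -65%, with a range from -85% to -40%.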

Compound 3, a percentage reported as activity, at one concentration (the size of the read-out at that concentration, not a potency): -99%
Compound 3: the middle estimate sits 34 percentage points above what was measured; the whole stated range lies above it.
By their numbers in this assay, from the lowest: compound 3; then compounds 1 and 2 (each within the scatter of the next).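

In this assay, going from the 4-chloro-3-(trifluoromethyl)phenyl group to the 3-(trifluoromethyl)phenyl group gives a number 22 percentage points lower from compound 1 to compound 3 (beyond the scatter), which shows that a chloro at this position, ortho to a trifluoromethyl group, is not needed for the effect and that hydrogen there gives the stronger result. Replacing a trifluoromethyl group with hydrogen points the same way, with a number 29 percentage points lower from compound 2 to compound 3 (beyond the scatter), so compound 3 is the strongest of the three at the concentration tested. No supporting measurement accompanies these steps, and the reason for them remains unknown.

The compounds shown leave open whether hydrogen is uniquely favourable at this position, or whether a fluoro, methoxy or amino group there would do as well. They also do not show whether the remaining trifluoromethyl group contributes to the effect.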